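A few compounds are considered here, and "the series" means these few. Any claim that something is new, unique, unknown or untested is made for them only; others in the source may bear on it.

Compound 1 `C=C1C(=O)[C@]23C[C@@]1(O)CC[C@H]2c1ccc(O)c(C)c1[C@@H]3Cn1cc(-c2ccc(F)cc2)nn1` and compound 3 `C=C1C(=O)[C@]23C[C@@]1(O)CC[C@H]2c1ccc(O)c(C)c1[C@@H]3Cn1cc(-c2ccc(OC)cc2)nn1` share one core and differ only by methoxy in place of fluoro on an aromatic carbon. In a functional assay on SW480 cells (Homo sapiens) for cytotoxicity, read by MTT assay, with a stated time of 4 days (on this read-out higher numbers stand for weaker inhibition and lower numbers for stronger inhibition), compound 1 gives 250 nM. In this assay compound 3 gives 220 nM. The change made a 1.1-fold lower number from compound 1 to compound 3 (0.06 log units; within the scatter). Compound 2 `C=C1C[C@]23C[C@@]1(O)CC[C@H]2c1ccc(O)c(C)c1[C@@H]3Cn1cc(-c2ccc(F)cc2)nn1` carries a second core; the difference between the two cores is not broken down here. In this assay compound 2 reaches only a limit of the assay, > 20000 nM, which sits at the limit of > 20000 nM in this assay, at which 1 of the 3 values shown sits. Compound 4 `C=C1C[C@]23C[C@@]1(O)CC[C@H]2c1ccc(O)c(C)c1[C@@H]3Cn1cc(-c2ccc(OC)cc2)nn1` stands to compound 2 as compound 3 stands to compound 1, the change being (methoxy in place of fluoro on an aromatic carbon), the same change at the same place. Since that change gave a 1.1-fold lower number from compound 1 to compound 3 (0.06 log units; within the scatter), compound 4 is expected to stay where compound 2 stands, and the step expected is a step that the limit leaves unreadable from compound 2 to compound 4. For compound 4 the estimate in this assay is 25000 nM, probably again only a limit, roughly between 8000 nM and 80000 nM.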

Compound 4, half-maximal inhibitory concentration: > 20000 nM
Compound 4: a limit, no number; the forecaster's own chance of this, stated with the estimate: 80%; the middle value is on the limit's open side.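

Compound 2 and compound 4 both give only a limit in this assay, so no step between them can be read: the limit of > 20000 nM in this assay, at which 2 of the 4 values shown sit.

As far as these compounds go, whether methoxy in place of fluoro changes anything on this core remains open, as neither compound gives a number.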